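This account rests on a few compounds, and the source may have more. Where it says the series, first, only, none or still open, it means among the compounds named here.

In a functional assay on CCRF-CEM cells (Homo sapiens) for antiproliferative activity, read by MTT assay, with a stated time of 72 h, tested at 25 uM (a higher number here means a weaker effect of the compound at the concentration tested, a lower number a stronger effect), the measured compounds are: compound 1 `COC(C(=O)OC(C)Cn1cnc2c1c(=O)n(C)c(=O)n2C)c1cccc2ccccc12`, 96.6%; compound 2 `CC(Cn1cnc2c1c(=O)n(C)c(=O)n2C)OC(=O)Sc1ccccc1`, 53.9%; compound 3 `CC(Cn1cnc2c1c(=O)n(C)c(=O)n2C)OCc1cn(-c2cccc3ccccc23)nn1`, 90%.

Compound 1 gives the highest of these three numbers. Its nearest neighbour is compound 3, whose number lies within the scatter of that of compound 1; compound 2 stands farthest away, beyond the scatter. Compound 4 `COC(C(=O)OC(C)Cn1cnc2c1c(=O)n(C)c(=O)n2C)c1ccc(C(C)(C)C)cc1` awaits measurement in this assay. It differs from compound 1 in one place: 4-(tert-butyl)phenyl in place of naphthalen-1-yl on a saturated chain carbon bound to a carbonyl carbon and an oxygen on a saturated carbon. Among the compounds with values here, no two measured compounds differ in a single place, so no measured step speaks directly to this exchange. Because compound 1 gives 96.6%, a number showing almost no effect, the expected step of a number 4.6 percentage points lower from compound 1 to compound 4 (within the scatter) is small and within the scatter. For compound 4 the estimate is 92%, with a range from 78% to 102%.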

Compound 4, a percentage reported as activity, at one concentration (the size of the read-out at that concentration, not a potency): 75.8%
Compound 4: middle estimate off by 16.2 percentage points, on the high side, and the stated range ends above it.
By their numbers in this assay, from the lowest: compound 2; then compound 4; then compounds 3 and 1 (each within the scatter of the next).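

In this assay the exchange on this saturated chain carbon gives a number 20.8 percentage points lower from compound 1 to compound 4 (beyond the scatter) and so a stronger effect, showing that this position does not treat these two groups alike. The change keeps the heavy-atom count and the all-carbon makeup, while two six-membered aromatic rings give way to one. No available evidence accounts for the shift.

From the compounds shown here alone, whether the step comes from the tert-butyl group or from the loss of the second ring stays open. A plain phenyl group at this place would bear on that question.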